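Dimethylamino in place of amino: weakly cytotoxic series

This account rests on a few compounds, and the source may have more. Where it says the series, first, only, none or still open, it means among the compounds named here.

In an ADME assay on L1210/0 cells (Mus musculus) for cytotoxicity, with a stated time of 48 h (a lower number here means a stronger inhibitor, a higher number a weaker inhibitor), compound 1 (`Nc1nc2c(nc(I)n2COCCO)c(=O)[nH]1`) gives 111000 nM. Compound 2 (`Nc1nc2c(nc(N)n2COCCO)c(=O)[nH]1`) has only a limit, > 200000 nM. Compound 3 (`CN(C)c1nc2c(=O)[nH]c(N)nc2n1COCCO`) differs from it as follows: dimethylamino in place of amino on an aromatic carbon. Among the compounds with values here, the one measured step bearing on this change is at the same carbon, amino in place of iodo, and it is an at least 1.8-fold higher number from compound 1 to compound 2 (0.25 log units; that floor lies within the scatter). On that evidence, no change beyond the scatter is expected in this assay. The expected step is a number no higher from compound 2 to compound 3 (the limit leaves the size open). For compound 3 the estimated value is 200000 nM, with an expected range of 100000 nM to 400000 nM.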

Compound 3, half-maximal inhibitory concentration: > 200000 nM
Compound 3 was reported as a limit; the forecaster's own chance of this, stated with the estimate: 65%; the middle value lies on the limit itself.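

In this assay, dimethylamino in place of iodo on this aromatic carbon gives an at least 1.8-fold higher number from compound 1 to compound 3 (0.25 log units; that floor lies within the scatter). Compound 3 is reported only as a limit, and the step between compound 2 and compound 3 cannot be read: the limit of > 200000 nM in this assay, at which 2 of the 3 values shown sit. Amino and dimethylamino at this carbon therefore both end at a limit, and neither gives a readable number.

Going by these compounds, whether a halogen such as bromo, or a carbon-linked group such as methyl or phenyl, would give a readable number at this carbon stays open. So does the effect of a longer chain in place of the (2-hydroxyethoxy)methyl group.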